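One Aromatic Ring Exchanged in a Dihydrofolate Reductase Inhibitor

The source may hold more compounds than are shown below. What is called first, only, known or untested is meant among the compounds shown, and "the series" means these compounds.

Compound 1 `NC1=NC2(CCOCC2)N(OCCCOc2cccc(Cl)c2)C(N)=N1`: 85.8%
Compound 2 `NC1=NC2(CCOCC2)N(OCCCOc2ccc(F)cc2)C(N)=N1`: "not determined" (no result reported)

Compound 1 stands alone on the numbers shown: in an assay on isolated protein for inhibition of Dihydrofolate reductase (Homo sapiens), read by spectrophotometry, using NADPH, with stated times of 5 s and 6 min, tested at 50 uM (a lower number here means a weaker effect, a higher number a stronger effect of the compound at the concentration tested), compound 1 gives 85.8%, the only figure available, while compound 2 has no reported result. Compound 3 `Cc1cc(C)cc(OCCCON2C(N)=NC(N)=NC23CCOCC3)c1` keeps the shared core and differs from compound 1 in one place: 3,5-dimethylphenyl in place of 3-chlorophenyl on an oxygen on a saturated carbon. Going by the values given here, no measured pair here shows what such a change does, so its size is open; a step that stays within the usual scatter, or leans slightly downward, seems most likely. The expected step is a number 5.8 percentage points lower from compound 1 to compound 3 (within the scatter). Compound 3 is thus estimated at 80%, in the range 60% to 92%.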

Compound 3, a percentage reported as inhibition, at one concentration (the size of the read-out at that concentration, not a potency): 88.6%
Compound 3: middle estimate off by 8.6 percentage points, on the low side; measured number inside the range.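

In this assay, putting 3,5-dimethylphenyl in place of 3-chlorophenyl on an oxygen on a saturated carbon gives a number 2.8 percentage points higher from compound 1 to compound 3 (within the scatter) and so stays within the usual scatter. For this pair, then, the chlorine is not needed to keep the read-out at this level, and the two methyl groups serve as well. Nothing measured here explains this result. Going by these compounds, what a ring carrying an amine or a carboxylic acid would give remains open, as does a longer chain linking the ring to the shared core. A reading at one concentration also leaves the potencies of compound 1 and compound 3 unknown.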